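Butoxy and Chlorophenyl Analogues in an Antiproliferative Cell Assay

This account rests on a few compounds, and the source may have more. Where it says the series, first, only, none or still open, it means among the compounds named here.

Measured compounds:
compound 1 `CCCCOC1(c2ccc(Br)cc2)SC=C(C)n2c1noc2=O` gives 78000 nM in a functional assay on A2780/DX3 cells (Homo sapiens) for antiproliferative activity, read by MTT assay, with a stated time of 3 days; on this read-out higher numbers stand for weaker inhibition and lower numbers for stronger inhibition;
compound 2 `CC/C=C/COC1(c2ccc(Br)cc2)SC=C(C)n2c1noc2=O` gives 111000 nM in this assay;
compound 3 `CC/C=C/COC1(c2ccc(Cl)cc2)SC=C(C)n2c1noc2=O` gives 88000 nM in this assay.

All three numbers sit close together, and none of the steps between them reaches beyond the scatter. The step of a 1.4-fold lower number from compound 2 to compound 1 (0.15 log units; within the scatter) is made by the change (propyl in place of but-1-en-1-yl on a saturated chain carbon bound to an oxygen on a saturated carbon). The step of a 1.3-fold lower number from compound 2 to compound 3 (0.10 log units; within the scatter) is made by the change (chloro in place of bromo on an aromatic carbon), which is also how the core of compound 3 differs from the core of compound 2.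

Compound 4 `CCCCOC1(c2ccc(Cl)cc2)SC=C(C)n2c1noc2=O` has not been measured. It differs from compound 3 by propyl in place of but-1-en-1-yl on a saturated chain carbon bound to an oxygen on a saturated carbon. For the measured compounds named here, this is the same change as the one from compound 2 to compound 1, and it sits at the same place in both pairs, so the earlier step is the only direct guide. Since that step was a 1.4-fold lower number from compound 2 to compound 1 (0.15 log units; within the scatter) and fell within the scatter, the step from compound 3 to compound 4 is expected to be small as well, estimated as a 1.4-fold lower number from compound 3 to compound 4 (0.13 log units; within the scatter), resting on compound 3 giving 88000 nM and compound 1 giving 78000 nM.

On this basis compound 4 is expected to give about 65000 nM in this assay, with a likely range from 30000 nM to 140000 nM.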

Compound 4, half-maximal inhibitory concentration: 49000 nM
Compound 4: the middle estimate sits 1.3-fold (0.12 log units) above what was measured, within the range that was stated.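

Carried onto the core of compound 3, propyl in place of but-1-en-1-yl gives a 1.8-fold lower number from compound 3 to compound 4 (0.25 log units; within the scatter) in this assay, and this agrees with what the same change gave on the core of compound 2: the same change on two cores in this assay, a 1.4-fold lower number (0.15 log units; within the scatter) from compound 2 to compound 1 and a 1.8-fold lower number (0.25 log units; within the scatter) from compound 3 to compound 4, 1.3-fold (0.10 log units) apart, within the scatter of two such steps

Chloro in place of bromo behaves the same way, with a 1.6-fold lower number from compound 1 to compound 4 (0.20 log units; within the scatter) on the butoxy compounds, and this also agrees with the earlier step: the same change on two cores in this assay, a 1.3-fold lower number (0.10 log units; within the scatter) from compound 2 to compound 3 and a 1.6-fold lower number (0.20 log units; within the scatter) from compound 1 to compound 4, 1.3-fold (0.10 log units) apart, within the scatter of two such steps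

For the compounds shown here, both changes therefore carry from one core to the other with no difference that can be told from the scatter, but every step here lies within that scatter, so the four compounds do not show that either change has a real effect of its own, and agreement between such small steps on only two cores says little about how a larger step would carry over.

The compounds shown cover only butoxy and (pent-2-en-1-yl)oxy together with bromo and chloro, and all of them stay close together in this assay. On these data alone, whether a longer chain in place of butoxy, or an amine or a carboxylic acid in place of chloro, would move the number beyond the scatter remains open.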